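Swapping an amine chain for an amide on compound 1

A few compounds are considered here, and "the series" means these few. Any claim that something is new, unique, unknown or untested is made for them only; others in the source may bear on it.

Measured compounds: compound 1 `O=C(OC1CCCN(CCCc2ccccc2)C1)c1ccccc1-c1ccccc1` gives 6500 nM; compound 2 `CC1CC(=O)N(c2ccccc2C(=O)OCC2CCCN(CCCCCc3ccccc3)C2)C1=O` gives 24500 nM; compound 3 `O=C(OCC1CCCN(CCCCCOc2ccc(Cl)cc2)C1)c1ccccc1-c1ccccc1` gives 14500 nM, all in an in vitro functional assay on HEK ts201 cells for antagonist activity at Neuronal acetylcholine receptor; alpha4/beta2 (Homo sapiens), read by fluorescence and calcium flux; a lower number here means a stronger inhibitor, a higher number a weaker inhibitor.

Among these three, compound 1 has the lowest number, and its gaps to compound 3 and compound 2 both lie beyond the scatter, so it is the strongest inhibitor of the set. The unmeasured compound 4 `O=C(OC1CCCN(C(=O)CCc2ccccc2)C1)c1ccccc1-c1ccccc1` is built from compound 1 by one change: phenethylcarbonyl in place of 3-phenylpropyl on an amine nitrogen in a ring. For the measured compounds named here, no measured pair shows this exact change, so its effect is unknown here. The expectation is a rise in the number, a step beyond the scatter, with compound 4 expected at 20000 nM (range 5000 nM to 80000 nM), a step of a 3.1-fold higher number from compound 1 to compound 4 (0.49 log units; beyond the scatter).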

Compound 4, half-maximal inhibitory concentration: 4300 nM
Beside the measured number, compound 4's estimate is 4.7-fold (0.67 log units) above it; measured number outside the range, below it.
By their numbers in this assay, from the lowest: compounds 4 and 1 (each within the scatter of the next); then compounds 3 and 2 (each within the scatter of the next).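

In this assay the swap of 3-phenylpropyl for phenethylcarbonyl on an amine nitrogen in a ring gives a 1.5-fold lower number from compound 1 to compound 4 (0.18 log units; within the scatter) and so leaves the inhibition unchanged within the scatter. At this position, then, a carbonyl attached directly to the ring nitrogen is tolerated, and inhibition in this pair does not require the amine form of compound 1. Nothing here explains why the two compounds read alike.

Still open, as far as these compounds go, is whether a sulfonyl group in place of the carbonyl, or a longer chain on the carbonyl, would keep this level of inhibition.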